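Aryl swap on the piperazine amide of compound 1

The source may hold more compounds than are shown below. What is called first, only, known or untested is meant among the compounds shown, and "the series" means these compounds.

Among the measured compounds shown here, compound 1 `Cc1nc(-c2ccccc2)c(C(=O)N2CCN(c3cccc(C#N)c3)CC2)o1` is the reference point of the set: in a functional assay on HL-60 cells (Homo sapiens) for inhibition, read by MTT assay, with a stated time of 72 h (a higher number here means a weaker inhibitor, a lower number a stronger inhibitor), compound 1 gives 39.6 nM, the only full number in hand. Compound 2 `CC(C)(C)c1nc(-c2ccccc2F)c(C(=O)N2CCN(c3cccc(Cl)c3)CC2)o1` returns only a limit of the assay, and in this assay compound 2 reads > 1000 nM. Compound 3 `COc1cccc(-c2nc(C)oc2C(=O)N2CCN(c3cccc(Cl)c3)CC2)c1` is recorded in this assay as "not active" (no number reported), without a number. For the measured compounds named here, compounds 2 and 3 each differ from compound 1 in more than one place, so no single-change step between measured compounds is available, and neither compound serves as a guide for a change made on the amine nitrogen alone. The one shown limit is the limit of > 1000 nM in this assay, at which 1 of the 3 values shown sits.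

Compound 4 `Cc1nc(-c2ccccc2)c(C(=O)N2CCN(c3ccc(C)c(C)c3)CC2)o1` is not yet measured. It differs from compound 1 in one place: 3,4-dimethylphenyl in place of 3-cyanophenyl on an amine nitrogen in a ring. Going by the values given here, with no measured step of this kind to lean on, the expectation is a modest weakening that may still fall inside the usual scatter of repeated measurements, with a real chance that the result lands beyond it. The estimated step from compound 1 to compound 4 in this assay is a 3.0-fold higher number from compound 1 to compound 4 (0.48 log units; beyond the scatter). For compound 4 the expected value in this assay is 120 nM, with a range from 30 nM to 600 nM.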

Compound 4, half-maximal inhibitory concentration: 43 nM
For compound 4 the middle estimate is 2.8-fold (0.45 log units) above the measured one; low and high end bracket the measured number.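

In this assay, among the compounds shown here, the first single-change step at this position reads a 1.1-fold higher number from compound 1 to compound 4 (0.04 log units; within the scatter), so 3,4-dimethylphenyl on the amine nitrogen in a ring and 3-cyanophenyl cannot be told apart here. The nitrile and its hydrogen-bond acceptor can therefore leave this position, replaced by an aryl group made of carbon only, without a reading beyond the scatter, something compounds 2 and 3 could not show because each differs from compound 1 in more than one place. Nothing in hand bears on why the two groups read alike.

As far as these compounds go, both groups compared here are uncharged substituted phenyl rings, so it remains open whether this tolerance extends to a phenyl ring carrying a carboxylic acid or an aminomethyl group, or to a saturated ring such as cyclohexyl on the same nitrogen. For the compounds shown here, no step to compound 2 or compound 3 can be read, so it also remains open whether 3-chlorophenyl at this position is compatible with activity when the rest of compound 1 is kept unchanged.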